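Removing a Methoxy Group: One Change, Two Surroundings

The source may hold more compounds than are shown below. What is called first, only, known or untested is meant among the compounds shown, and "the series" means these compounds.

Of the compounds shown here, three sharing the same core have been tested in a functional assay on KBVIN cells (Homo sapiens) for antiproliferative activity, read by sulforhodamine B assay, with a stated time of 3 days; a lower number here means that less compound is needed, a higher number that more compound is needed for the effect. Compound 1 `CCC1=C(O)c2c(oc(-c3cccc(C)c3)cc2=O)C(CC)(CC)C1=O` gives 3.69 uM. Compound 2 `CCC1=C(O)c2c(oc(-c3ccc(OC)c(C)c3)cc2=O)C(CC)(CC)C1=O` gives 0.1 uM, and compound 3 `CCC1=C(O)c2c(oc(-c3ccc(OC)c(OC)c3OC)cc2=O)C(CC)(CC)C1=O` gives 1.57 uM. Compound 2 and compound 3 differ in more than one place, so the difference between their cores is not broken down here.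

The step from compound 2 to compound 1 is hydrogen in place of methoxy on an aromatic carbon and it produced a 37-fold higher number from compound 2 to compound 1 (1.57 log units; beyond the scatter).

Compound 4 `CCC1=C(O)c2c(oc(-c3cccc(OC)c3OC)cc2=O)C(CC)(CC)C1=O` has not yet been tested in this assay. It arises from compound 3 by hydrogen in place of methoxy on an aromatic carbon. Within the data shown here, this is the same kind of change as the one from compound 2 to compound 1, not the same change: here the spot sits ortho to a methoxy group and meta to a methoxy group, whereas in compound 2 it sat ortho to a methyl group.

Because removing the methoxy gave a 37-fold higher number from compound 2 to compound 1 (1.57 log units; beyond the scatter), a rise is expected for compound 4 too, though a smaller one, since its surroundings differ. The expected step is a 5.1-fold higher number from compound 3 to compound 4 (0.71 log units; beyond the scatter). Compound 4 is estimated at 8 uM, between 2 uM and 30 uM.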

Compound 4, concentration for half-maximal effect: 4.02 uM
Compound 4: middle estimate off by 2.0-fold (0.30 log units), on the high side, within the range that was stated.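

Replacing a methoxy group with hydrogen again raises the number in this assay, giving a 2.6-fold higher number from compound 3 to compound 4 (0.41 log units; beyond the scatter), so the direction of the change is the same on both cores. The size of the effect, however, does not carry over from one core to the other: the same change on two cores in this assay, a 37-fold higher number (1.57 log units; beyond the scatter) from compound 2 to compound 1 and a 2.6-fold higher number (0.41 log units; beyond the scatter) from compound 3 to compound 4, 14-fold (1.16 log units) apart, beyond the scatter of two such steps

Among these compounds, with only two pairs, this shows that a step measured on one core is a poor guide to its size on another, but it does not show what sets the size, since the methyl group kept in compound 1 and the two methoxy groups kept in compound 4 are just one of the contrasts that could matter. It also gives no rule for other cores in this series.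

Still open, from the compounds shown here alone, is how other groups at the same spot, such as an amine or a chlorine atom, would compare with methoxy and hydrogen on these cores. Also open, going by these compounds, is whether a core carrying an ethoxy group there would respond more like compound 2 or more like compound 3.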